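A few compounds are considered here, and "the series" means these few. Any claim that something is new, unique, unknown or untested is made for them only; others in the source may bear on it.

Measured compounds:
compound 1 `Cc1cccc2c(NCc3ccco3)nc(NC(C)C)nc12` gives 45.9 10^-6 cm/s in a physicochemical assay for permeability, using PAMPA, at pH 4; on this read-out higher numbers stand for higher permeability and lower numbers for lower permeability;
compound 2 `Cc1ccc2c(NCc3ccco3)nc(NC(C)C)nc2c1` gives 67.2 10^-6 cm/s in this assay;
compound 3 `COc1cccc2c(NCc3ccco3)nc(NC(C)C)nc12` gives 38.4 10^-6 cm/s in this assay.

Compound 1 and compound 2 are built from the same atoms joined differently; the difference between the two cores is not broken down here. Compound 3 arises from compound 1 by methoxy in place of methyl on an aromatic carbon. That step gave a 1.2-fold lower number from compound 1 to compound 3 (0.08 log units; within the scatter), so the two numbers cannot be told apart by this assay. Compound 2 stands with the highest of the three numbers, yet its gaps to compound 1 and to compound 3 are both within the scatter, so no order among the three is claimed.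

Compound 4 `COc1ccc2c(NCc3ccco3)nc(NC(C)C)nc2c1` has not yet been measured. It arises from compound 2 by methoxy in place of methyl on an aromatic carbon. Among the compounds with values here, this is the same kind of change as the one from compound 1 to compound 3, but the place is not the same: in compound 3 the methoxy sits ortho to a fused ring and meta to a fused ring, whereas in compound 4 it sits meta to a fused ring and para to a fused ring. Within the data shown here, the only guide is the earlier step, which stayed within the scatter. On that basis the step from compound 2 to compound 4 is expected to be small, about a 1.2-fold lower number from compound 2 to compound 4 (0.08 log units; within the scatter), resting on the outcome of a 1.2-fold lower number from compound 1 to compound 3 (0.08 log units; within the scatter). Compound 4 is therefore estimated to give about 56 10^-6 cm/s in this assay, with a likely range from 35 10^-6 cm/s to 85 10^-6 cm/s.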

Compound 4, apparent permeability: 59.2 10^-6 cm/s
Compound 4: middle estimate off by 1.1-fold (0.02 log units), on the low side; low and high end bracket the measured number.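

In this assay, methoxy in place of methyl on an aromatic carbon gave a 1.1-fold lower number from compound 2 to compound 4 (0.06 log units; within the scatter) on one core and a 1.2-fold lower number from compound 1 to compound 3 (0.08 log units; within the scatter) on the other, so the step lies within the scatter on both cores and, for these two pairs, carrying the change from one core to the other gave the same reading. This does not show that the change does nothing, only that the assay cannot tell the members of either pair apart, and the agreement rests on just two pairs, with the methoxy at a different place in each, meta to a fused ring and para to a fused ring in compound 4. The data shown offer no measurement that would explain why either step is as small as it is.

The compounds shown leave open whether a different group at the place held by methoxy in compound 4, such as an amine, a carboxylic acid or a longer chain, would move the number beyond the scatter. They also leave open whether the methoxy step would stay this small on any core other than these two.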